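Series notes: nitrophenyl variation on the diamine core

The compounds below may be only part of what the source reports. "The series", "measured", "known", "first", "only" and "open" are said of these compounds alone.

Measured so far:
compound 1 `COC(=O)c1ccc(CN(CCCc2c(N)nc(N)nc2O)c2cc(F)c(F)cc2[N+](=O)[O-])cc1` — 53000 nM
compound 2 `CC(C)(C)OC(=O)CCC(Nc1ccc(CN(CCCc2c(N)nc(N)nc2O)c2cc(F)cc(F)c2[N+](=O)[O-])cc1)C(=O)OC(C)(C)C` — 7700 nM
compound 3 `Nc1nc(N)c(CCCN(Cc2ccc(NC(CCC(=O)O)C(=O)O)cc2)c2cc(F)ccc2[N+](=O)[O-])c(O)n1` — > 100000 nM

The read-out throughout is a functional assay on CCRF-CEM cells (Homo sapiens) for cytotoxicity, in the presence of a further agent that is not named here; on this read-out lower numbers stand for stronger inhibition and higher numbers for weaker inhibition. Compound 2 gives 7700 nM, the lowest of the two numbers in hand. Compound 1 gives 53000 nM, which stands a fair distance above compound 2, a gap beyond the usual scatter. Compound 3 is reported only as a limit of the assay, > 100000 nM, and not as a number; (the limit of > 100000 nM in this assay, at which 1 of the 3 values shown sits).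

Compound 4 `CC(C)(C)OC(=O)CCC(Nc1ccc(CN(CCCc2c(N)nc(N)nc2O)c2cc(F)c(F)cc2[N+](=O)[O-])cc1)C(=O)OC(C)(C)C` has not yet been measured. It shares all atoms with compound 2 and differs only in how they are joined: 4,5-difluoro-2-nitrophenyl in place of 3,5-difluoro-2-nitrophenyl on an amine nitrogen. For the measured compounds named here, no measured pair in the set isolates this change, so its effect cannot be read off directly. Going by the values given here, with no comparable step to lean on, the expectation for compound 4 is a number close to compound 2, allowing for a modest shift in either direction, most likely toward a somewhat higher number. The estimate for compound 4 is 12000 nM, with a range from 3500 nM to 45000 nM. The step that this estimate implies is a 1.6-fold higher number from compound 2 to compound 4 (0.19 log units; within the scatter), expected to fall near the edge of the scatter rather than clearly beyond it.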

Compound 4, half-maximal inhibitory concentration: 3100 nM
Compound 4: the middle estimate sits 3.9-fold (0.59 log units) above what was measured; the measured number lies below the stated range.
By their numbers in this assay, from the lowest: compound 4; then compound 2; then compound 1. At a limit, above all of these: compound 3.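

In this assay, 4,5-difluoro-2-nitrophenyl in place of 3,5-difluoro-2-nitrophenyl on an amine nitrogen gives a 2.5-fold lower number from compound 2 to compound 4 (0.40 log units; beyond the scatter), a modest step but one that lies beyond the scatter. For the compounds shown here, this is the first pair in the set that differs in one place, and it shows that this position responds to the arrangement of the two fluorines alone, since the two groups match in heavy atoms, hydrogen-bond donors, hydrogen-bond acceptors and net charge. Nothing in the data given bears on why the rearrangement moves the number in this direction.

On these data alone, it remains open whether the step is specific to fluorine or to the nitro group, which a chlorine in place of either fluorine, or an amine in place of the nitro group, would help to separate. As far as these compounds go, it is equally open whether the same step would appear with other groups on the far side of the amine nitrogen, such as the free carboxylic acids in place of the tert-butyl esters.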